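Acid-to-methoxy swap at the chain-terminal aryl ether

A few compounds are considered here, and "the series" means these few. Any claim that something is new, unique, unknown or untested is made for them only; others in the source may bear on it.

Of the compounds shown here, two have numbers so far. Compound 1 `Cc1ccc(OCCCCOc2ccc(C(=O)CC(C)(C)C)c(O)c2C)cc1C(=O)O` gives 210 nM in an assay for positive allosteric modulation of metabotropic glutamate receptor 2 (Rattus norvegicus); a lower number here means that less compound is needed, a higher number that more compound is needed for the effect. Compound 2 `Cc1cc(C(=O)O)ccc1OC[C@H](C)COc1ccc(C(=O)CC(C)(C)C)c(O)c1C` gives 446 nM in this assay, the higher of the two numbers, a gap beyond the usual scatter. Compound 3 `COc1cccc(OC[C@H](C)COc2ccc(C(=O)CC(C)(C)C)c(O)c2C)c1` remains to be measured; it differs from compound 2 by 3-methoxyphenyl in place of 4-carboxy-2-methylphenyl on an oxygen on a saturated carbon. For the measured compounds named here, no step of this kind has been measured, so the expected step of a 3.4-fold higher number from compound 2 to compound 3 (0.53 log units; beyond the scatter) rests only on the change itself, and a rise is anticipated because compound 2 already gives 446 nM. For compound 3 the estimate in this assay is 1500 nM, with a range from 400 nM to 6000 nM.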

Compound 3, half-maximal effective concentration: "not active" (no number reported)
Compound 3 has no reported number here; there is nothing to compare the estimate with.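

For the compounds shown here, compound 3 is reported as not active, without a number, so no step from compound 2 to compound 3 can be read, and nothing on hand bears on this result.

In this assay, from the compounds shown here alone, the size of the change on going from 4-carboxy-2-methylphenyl to 3-methoxyphenyl stays open.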